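Working notes: from compound 2 to compound 4

A few compounds are considered here, and "the series" means these few. Any claim that something is new, unique, unknown or untested is made for them only; others in the source may bear on it.

Measured so far:
- compound 1 `C/C(=N\O)c1ccc(NC(=O)Cn2nc(-c3ccc(Cl)cc3)nc2N)cc1` gives 17.8%
- compound 2 `C/C(=N/O)c1ccc(NC(=O)Cn2nc(C(F)(F)F)nc2N)cc1` gives 12.9%
- compound 3 `C/C(=N/O)c1ccc(NC(=O)Cn2nc(-c3ccccc3)nc2N)cc1` gives 3.91%

The read-out throughout is a functional assay on NCI-H226 cells (Homo sapiens) for inhibition, read by sulforhodamine B assay, with a stated time of 48 h, tested at 10 uM; on this read-out higher numbers stand for more inhibition of growth at the one concentration tested and lower numbers for less inhibition of growth. On this measure, compound 2 (12.9%) lies within the scatter of both compound 1 (17.8%) and compound 3 (3.91%), so it offers no clear separation from either.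

The next structure is compound 4 `CC(=O)c1ccc(NC(=O)Cn2nc(C(F)(F)F)nc2N)cc1`, which keeps the trifluoromethyl group of compound 2 and changes one place only: a group of 3 heavy atoms (2 carbon, 1 oxygen; no ring) in place of a group of 4 heavy atoms (2 carbon, 1 nitrogen, 1 oxygen; no ring), on an aromatic carbon. Acetyl enters on an aromatic carbon of a six-membered aromatic ring of carbon only, para to a large group.

Only one measured step connects two of these compounds, a number 9 percentage points lower from compound 2 to compound 3 (within the scatter). That step swaps phenyl for trifluoromethyl at another place, so it bears on the new change only indirectly. Going by the values given here, it shows a single-place change that stays within the scatter, but no measured step touches the place that changes in compound 4. The data therefore give no basis for a direction, and no step beyond the scatter is expected in this assay.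

The estimated outcome is a number 0.9 percentage points lower from compound 2 to compound 4 (within the scatter). Compound 4 is expected at 12% (estimated range 2% to 25%).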

Compound 4, percent growth inhibition at one concentration: 8.52%
Estimate against measurement, compound 4: 3.5 percentage points above, within the range that was stated.
By their numbers in this assay, from the lowest: compounds 3, 4, 2 and 1 (each within the scatter of the next, the first and the last beyond it).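

In this assay, acetyl in place of the group of 4 heavy atoms, on an aromatic carbon para to a large group, gives a number 4.4 percentage points lower from compound 2 to compound 4 (within the scatter). Going by these compounds alone, this is the first measured step at this place, since the earlier step concerned the place held by trifluoromethyl, and it shows that this exchange does not separate the two compounds on this read-out, even though the 1 hydrogen-bond donor of the leaving group has no counterpart in acetyl. No measurement on hand explains the result or links it to any property of either group.

The compounds shown leave open whether an amine or a carboxylic acid at this same place would give a step beyond the scatter, since acetyl and the group it replaces are the only two groups seen here. Within the data shown here, they also leave open whether acetyl would give a similar step with phenyl or 4-chlorophenyl in place of trifluoromethyl, as the only step at this place has trifluoromethyl held constant.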